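Bromo-to-hydrogen step on the hydroxyphenyl amide

The source may hold more compounds than are shown below. What is called first, only, known or untested is meant among the compounds shown, and "the series" means these compounds.

Measured compounds:
compound 1 `O=C(Nc1ccc(Sc2nc3ccccc3s2)cc1)c1cc(Br)cc(Br)c1O` gives 4700 nM in an assay for inhibition of HSP60/HSP10 (Homo sapiens), with a stated time of 60 min; on this read-out higher numbers stand for weaker inhibition and lower numbers for stronger inhibition.
compound 2 `COc1ccc(Br)cc1C(=O)Nc1ccccc1` gives > 100000 nM in this assay, a limit of the assay and not a number.
compound 3 `COc1ccccc1C(=O)Nc1ccc(Sc2nc3ccccc3s2)c(Cl)c1` gives > 100000 nM in this assay, again a limit of the assay and not a number.

Within the data shown here, compound 1 stands as the only compound with a numerical value in this assay. Among the measured compounds shown here, compounds 2 and 3 share (the limit of > 100000 nM in this assay, at which 2 of the 3 values shown sit), so no measured step between two compounds exists, and nothing shows how a single change moves the read-out.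

Compound 4 `O=C(Nc1ccc(Sc2nc3ccccc3s2)cc1)c1cccc(Br)c1O` differs from compound 1 by hydrogen in place of bromo on an aromatic carbon. The change cuts the 3,5-dibromo-2-hydroxyphenyl to 3-bromo-2-hydroxyphenyl while the rest of compound 1 is kept.

For the measured compounds named here, no measured pair shows this change, so the size of the step can only be guessed. The step of a 2.6-fold higher number from compound 1 to compound 4 (0.41 log units; beyond the scatter) is expected to be a modest weakening, about at the edge of the usual scatter, with a real chance that compound 4 stays within scatter of compound 1. Compound 4 is accordingly expected to give 12000 nM in this assay, with a likely range from 4000 nM to 40000 nM. As far as these compounds go, whether compound 4 instead reaches the limit at which compounds 2 and 3 sit remains open until it is measured.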

Compound 4, half-maximal inhibitory concentration: 26000 nM
The estimate for compound 4 lay 2.2-fold (0.34 log units) below the measured number; the range from low to high includes it.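

Among these compounds, the only step between compounds differing in one place in this assay is a 5.5-fold higher number from compound 1 to compound 4 (0.74 log units; beyond the scatter), on taking hydrogen in place of bromo on an aromatic carbon. This gives the series its first reading of a single change: bromo at this position, meta to a large group and para to a hydroxy group, goes with the lower number, yet the 3-bromo-2-hydroxyphenyl compound 4 still gives a numerical value, so losing this one bromo does not carry the compound to the limit. Compounds 2 and 3 remain at a limit of the assay and not at a number, and each differs from compound 1 in more than one place: the limit of > 100000 nM in this assay, at which 2 of the 4 values shown sit.

Whether the step depends on bromo itself stays open, since no other group at this position, such as fluoro, an amine or a carboxylic acid, appears among the compounds shown. Also open, as far as these compounds go, is how the read-out answers to a single change at the remaining bromo or the hydroxy group of compound 4.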